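Sulfonamide aryl variants on a shared benzamide-type core

The source may report more compounds than this note shows. Statements on the series, on what has been measured and on what is new or still open speak of the compounds shown alone.

Measured so far:
compound 1 `COc1cc(N)c(Cl)cc1C(=O)CCC1CCN(CCNS(=O)(=O)c2ccc(NC(C)=O)cc2)CC1` — 7.7 nM
compound 2 `COc1cc(N)c(Cl)cc1C(=O)CCC1CCN(CCNS(=O)(=O)c2cc(Br)c(N)c(Br)c2)CC1` — 8.7 nM

In an assay on brain for displacement of a labelled ligand from 5-hydroxytryptamine receptor 4 (Cavia porcellus), with a stated time of 30 min, in the presence of a further agent that is not named here (a higher number here means a weaker inhibitor, a lower number a stronger inhibitor), compound 1 gives 7.7 nM and compound 2 gives 8.7 nM; the two numbers lie within the usual scatter of each other, so compound 2 is not separated from compound 1 on this assay. Within the data shown here, the one step recorded so far, a 1.1-fold higher number from compound 1 to compound 2 (0.05 log units; within the scatter), replaces the group on the sulfonyl sulfur and moves the number by less than the scatter.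

Compound 3 `COc1cc(N)c(Cl)cc1C(=O)CCC1CCN(CCNS(=O)(=O)c2cc(Br)ccc2Br)CC1` is not yet measured. It differs from compound 2 as follows: 2,5-dibromophenyl in place of 4-amino-3,5-dibromophenyl on a sulfonyl sulfur.

Among the measured compounds shown here, the only measured step that bears on this change is a 1.1-fold higher number from compound 1 to compound 2 (0.05 log units; within the scatter), which also exchanges the group on the sulfonyl sulfur and left the number essentially unchanged. For the measured compounds named here, on that basis no step beyond the scatter is expected for compound 3 in this assay, though the one earlier step is a thin basis and the new group carries neither of the counted donor or acceptor features. The expected step is a 1.4-fold higher number from compound 2 to compound 3 (0.14 log units; within the scatter). For compound 3 the estimate in this assay is 12 nM, with a range from 4 nM to 40 nM.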

Compound 3, inhibition constant: 16.3 nM
Beside the measured number, compound 3's estimate is 1.4-fold (0.13 log units) below it; the measured number falls inside the stated range.
By their numbers in this assay, from the lowest: compounds 1, 2 and 3 (each within the scatter of the next, the first and the last beyond it).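

In this assay, the group on the sulfonyl sulfur now gives its first step beyond the scatter, though a modest one: a 2.1-fold higher number from compound 1 to compound 3 (0.33 log units; beyond the scatter), with 2,5-dibromophenyl in place of 4-acetamidophenyl. The direct exchange with 4-amino-3,5-dibromophenyl gives a 1.9-fold higher number from compound 2 to compound 3 (0.27 log units; within the scatter), so compound 3 is not separated from compound 2, even though the entering group has 0 hydrogen-bond donors and 0 hydrogen-bond acceptors and the leaving group has 1 of each. No measurement at hand offers an explanation for either step.

Among these compounds, with only three aryl groups on the sulfonyl sulfur, and all three substituted, it remains open how a plain phenyl, a monobromophenyl or an aminophenyl without bromine would compare, and whether a non-aromatic group such as methyl or cyclohexyl would hold a number in this range. Also open, on these data alone, is the effect of a carboxylic acid on the aryl ring, or of a longer chain on the sulfonamide nitrogen, with the rest of the shared core unchanged.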